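A Trifluoromethyl Swap on a Shared Core

A few compounds are considered here, and "the series" means these few. Any claim that something is new, unique, unknown or untested is made for them only; others in the source may bear on it.

Compound 1 `CC[C@@H]1/C=C(\C)C[C@H](C)C[C@H](OC)[C@H]2O[C@@](O)(C(=O)C(=O)N3CCCC[C@H]3C(=O)O[C@H](/C(C)=C/[C@@H]3CC[C@@H](Oc4cccc(OC)c4)[C@H](OC)C3)[C@H](C)[C@@H](O)CC1=O)[C@H](C)C[C@@H]2OC` and compound 2 `CC[C@@H]1/C=C(\C)C[C@H](C)C[C@H](OC)[C@H]2O[C@@](O)(C(=O)C(=O)N3CCCC[C@H]3C(=O)O[C@H](/C(C)=C/[C@@H]3CC[C@@H](Oc4ccccc4)[C@H](OC)C3)[C@H](C)[C@@H](O)CC1=O)[C@H](C)C[C@@H]2OC` share one core and differ only in the group on the aromatic ring of the phenoxy substituent. In a functional assay on cells for inhibition, with Murine T-cell line (Mus musculus) as the target (a lower number here means a stronger inhibitor, a higher number a weaker inhibitor), compound 1 gives 3.4 nM, and compound 2 gives 5.4 nM. Compound 2 carries the higher of the two numbers shown, though the step of a 1.6-fold higher number from compound 1 to compound 2 (0.20 log units; within the scatter) lies within the scatter, so the two compounds are not told apart. Compound 3 `CC[C@@H]1/C=C(\C)C[C@H](C)C[C@H](OC)[C@H]2O[C@@](O)(C(=O)C(=O)N3CCCC[C@H]3C(=O)O[C@H](/C(C)=C/[C@@H]3CC[C@@H](Oc4ccc(C(F)(F)F)cc4)[C@H](OC)C3)[C@H](C)[C@@H](O)CC1=O)[C@H](C)C[C@@H]2OC` takes the next step from compound 2: trifluoromethyl in place of hydrogen on an aromatic carbon. For the measured compounds named here, the only measured step, from compound 1 to compound 2, also alters that same aromatic ring and was small; no measured step introduces a trifluoromethyl group, so its bearing is indirect. On that basis the step of a 1.0-fold higher number from compound 2 to compound 3 (0.01 log units; within the scatter) is expected to stay within the scatter. Compound 3 is therefore estimated at 5.5 nM in this assay, with a range from 2 nM to 15 nM.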

Compound 3, half-maximal inhibitory concentration: 35.8 nM
The estimate for compound 3 lay 6.5-fold (0.81 log units) below the measured number, and the stated range ends below it.
By their numbers in this assay, from the lowest: compounds 1 and 2 (each within the scatter of the next); then compound 3.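

In this assay, the aromatic ring of the phenoxy substituent turns out not to accept every group: trifluoromethyl in place of hydrogen, para to a large group, gives a 6.6-fold higher number from compound 2 to compound 3 (0.82 log units; beyond the scatter). Exchanging 3-methoxyphenyl for 4-(trifluoromethyl)phenyl gives an 11-fold higher number from compound 1 to compound 3 (1.02 log units; beyond the scatter), so this ring, where the loss of methoxy could not be told apart from the scatter, does respond to a change of substituent. Nothing available accounts for this weakening.

The compounds shown leave open whether the weakening belongs to the trifluoromethyl group itself or to its place on the ring. A methoxy group or an amine in that same place, or trifluoromethyl where compound 1 carries its methoxy, would begin to separate the two.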